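The source may report more compounds than this note shows. Statements on the series, on what has been measured and on what is new or still open speak of the compounds shown alone.

Three compounds share the core of compound 1, `O=C(CN(c1nc(Cl)nc2[nH]cnc12)C1CC1)N[C@@H](CCC(=O)OCc1ccccc1)C(=O)OCc1ccccc1`, and were compared in a functional assay on the whole organism (Tail, strain ICR) with Mus musculus as the target, in the tail flick test, with a stated time of 60 min, at a dose of 25 umol/kg by the oral route; a lower number here means a weaker effect, a higher number a stronger effect of the compound at the dose given. Compound 1 gives 53.7%. Compound 2, `CC[C@H](C)[C@H](NC(=O)CN(c1nc(Cl)nc2[nH]cnc12)C1CC1)C(=O)OCc1ccccc1`, gives 40.6%, and compound 3, `CSCC[C@H](NC(=O)CN(c1nc(Cl)nc2[nH]cnc12)C1CC1)C(=O)OCc1ccccc1`, gives 30.8%. Compound 3 holds the lowest of the three numbers: its gap to compound 2 lies within the scatter, whereas the step of a number 22.9 percentage points lower from compound 1 to compound 3 (beyond the scatter) lies beyond it. Compound 4, `NC(=O)CC[C@H](NC(=O)CN(c1nc(Cl)nc2[nH]cnc12)C1CC1)C(=O)OCc1ccccc1`, is the next member and differs from compound 3 by carbamoyl in place of methylsulfanyl on a saturated chain carbon, three bonds along the chain from an amide-type nitrogen and a carbonyl carbon. For the measured compounds named here, two measured steps touch this side chain. The step of a number 22.9 percentage points lower from compound 1 to compound 3 (beyond the scatter) shows that exchanging the group at this place can move the read-out well beyond the scatter, while a number 9.8 percentage points lower from compound 2 to compound 3 (within the scatter) stays within it. The step of a number 13.1 percentage points lower from compound 1 to compound 2 (beyond the scatter) concerns the carbon bound to the amide-type nitrogen and bears only loosely on the present change. Going by the values given here, no measured pair swaps methylsulfanyl for carbamoyl, so the direction rests mainly on compound 1, which carries benzyloxycarbonyl at this place and sits highest of the three. A modest rise for compound 4 is therefore expected, a number 9.2 percentage points higher from compound 3 to compound 4 (within the scatter), with wide uncertainty. The estimate for compound 4 is 40%, in the range 26% to 56%.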

Compound 4, a percentage reported as activity, at one dose (the size of the read-out at that dose, not a potency): 33.1%
The estimate for compound 4 lay 6.9 percentage points above the measured number, and the stated range covers the measured number.
By their numbers in this assay, from the lowest: compounds 3, 4 and 2 (each within the scatter of the next); then compound 1.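

In this assay, carbamoyl in place of methylsulfanyl gives a number 2.3 percentage points higher from compound 3 to compound 4 (within the scatter) and so leaves the read-out unresolved at this place, even though carbamoyl brings a hydrogen-bond donor that methylsulfanyl lacks. The comparison with the branched side chain gives a number 7.5 percentage points lower from compound 2 to compound 4 (within the scatter) for 2-carbamoylethyl in place of sec-butyl, so compound 2, compound 3 and compound 4 now read alike with three different side chains. Amino in place of benzyloxy on a carbonyl carbon gives a number 20.6 percentage points lower from compound 1 to compound 4 (beyond the scatter) and adds a third step beyond the scatter for compound 1, the only compound shown that carries the benzyloxycarbonyl group on this side chain.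

Still open, on these data alone, is whether a carboxylic acid, an amine or a longer chain ending in carbamoyl at this place would stay level with compound 4 or approach compound 1. Also open, as far as these compounds go, is whether a simple benzene ring on this side chain would match the benzyloxycarbonyl group of compound 1 in this assay and whether the ester on the other carbonyl carbon matters for the read-out. Nothing at hand accounts for these values.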